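Swapping a pyridinylmethyl arm for a furanyl group

This account rests on a few compounds, and the source may have more. Where it says the series, first, only, none or still open, it means among the compounds named here.

Measured compounds:
- Compound 1, `CCOC(=O)c1ccc(-c2nn(Cc3ccccc3OC)c3ccccc23)cc1`: 470 nM
- Compound 2, `CCOC(=O)c1ccc(-c2nn(Cc3ccc(OC)cc3)c3ccccc23)cc1`: 620 nM
- Compound 3, `CCOC(=O)c1ccc(-c2nn(Cc3cccnc3)c3ccccc23)cc1`: 5550 nM

All three share a common core and differ only in the group carried on the aromatic nitrogen. In a functional assay on cells (Platelet, Homo sapiens) for inhibition (on this read-out higher numbers stand for weaker inhibition and lower numbers for stronger inhibition), compound 3 gives the highest number of the three, standing a 9.0-fold higher number from compound 2 to compound 3 (0.95 log units; beyond the scatter) and a 12-fold higher number from compound 1 to compound 3 (1.07 log units; beyond the scatter). Compound 1 and compound 2 lie close to one another, their gap being a 1.3-fold higher number from compound 1 to compound 2 (0.12 log units; within the scatter).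

Compound 4, `CCOC(=O)c1ccc(-c2nn(-c3ccco3)c3ccccc23)cc1`, is the next step from compound 3. The change is furan-2-yl in place of (pyridin-3-yl)methyl on an aromatic nitrogen. Among the compounds with values here, no measured pair contains this change: every step seen so far swaps one arm for another while keeping the saturated chain carbon between the ring and the aromatic nitrogen, whereas here the chain carbon is removed and a five-membered ring replaces a six-membered one. The measured steps show only that the arm matters a great deal, since both a 12-fold higher number from compound 1 to compound 3 (1.07 log units; beyond the scatter) and a 9.0-fold higher number from compound 2 to compound 3 (0.95 log units; beyond the scatter) were sizeable. The expectation for compound 4 is therefore uncertain in direction, with a wide range on either side of compound 3. An estimated step of a 2.2-fold lower number from compound 3 to compound 4 (0.35 log units; beyond the scatter) is taken for compound 4. Compound 4 is expected to give about 2500 nM, within a range of 400 nM to 15000 nM.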

Compound 4, half-maximal inhibitory concentration: 340 nM
Beside the measured number, compound 4's estimate is 7.4-fold (0.87 log units) above it; measured number below the stated range.
By their numbers in this assay, from the lowest: compounds 4, 1 and 2 (each within the scatter of the next); then compound 3.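

In this assay, the aromatic nitrogen can carry a furan-2-yl ring with no saturated chain carbon between them, and replacing the (pyridin-3-yl)methyl group this way gives a 16-fold lower number from compound 3 to compound 4 (1.21 log units; beyond the scatter) in a single change. The other two comparisons, a 1.8-fold lower number from compound 2 to compound 4 (0.26 log units; within the scatter) and a 1.4-fold lower number from compound 1 to compound 4 (0.14 log units; within the scatter), put compound 4 level with both methoxybenzyl compounds, so among these four compounds the chain carbon and the methoxy-bearing ring are not needed to reach this range, and only compound 3 stands apart. Nothing measured here explains the large step from the pyridine compound to the furan compound.

This change removes the chain carbon and replaces the ring together, which leaves open how much of the step belongs to each part. A furan-2-ylmethyl group and a pyridin-3-yl ring bound directly to the aromatic nitrogen would each change only one of these parts, and a carboxylic acid in place of the ethyl ester would test a different part of the molecule altogether.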